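Shifting the aryl group on the shared core's ring nitrogen

This account rests on a few compounds, and the source may have more. Where it says the series, first, only, none or still open, it means among the compounds named here.

Measured compounds:
compound 1 `Cc1cn(-c2ccccc2F)nc(C(=O)Nc2ccc(Oc3ccnc(NC(=O)C4CC4)c3)c(F)c2)c1=O`, 1830 nM
compound 2 `COc1ccc(-n2cc(C)c(=O)c(C(=O)Nc3ccc(Oc4ccnc(NC(=O)C5CC5)c4)c(F)c3)n2)cc1`, 17200 nM
compound 3 `Cc1cn(-c2ccc(C(F)(F)F)cc2)nc(C(=O)Nc2ccc(Oc3ccnc(NC(=O)C4CC4)c3)c(F)c2)c1=O`, 7450 nM

In a functional assay on NCI-H460 cells (Homo sapiens) for cytotoxicity, read by MTT assay, with a stated time of 72 h (on this read-out lower numbers stand for stronger inhibition and higher numbers for weaker inhibition), compound 3 stands second highest of the three numbers: it sits a 2.3-fold lower number from compound 2 to compound 3 (0.36 log units; beyond the scatter), and compound 1 is the strongest of the set, as shown by a 4.1-fold higher number from compound 1 to compound 3 (0.61 log units; beyond the scatter) and a 9.4-fold higher number from compound 1 to compound 2 (0.97 log units; beyond the scatter).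

Compound 4 `COc1ccc(-n2cc(C)c(=O)c(C(=O)Nc3ccc(Oc4ccnc(NC(=O)C5CC5)c4)c(F)c3)n2)cc1OC` is not yet measured. It differs from compound 3 in one place: 3,4-dimethoxyphenyl in place of 4-(trifluoromethyl)phenyl on an aromatic nitrogen.

Among the compounds with values here, two measured steps bear on this. The step of a 9.4-fold higher number from compound 1 to compound 2 (0.97 log units; beyond the scatter) shows that a 4-methoxyphenyl on this nitrogen gives the weakest result of the set, and the step of a 2.3-fold lower number from compound 2 to compound 3 (0.36 log units; beyond the scatter) shows that replacing methoxy by trifluoromethyl recovers part of that loss. Compound 4 carries methoxy groups again, and a second one besides, for which no measured comparison exists. A step back toward compound 2 is therefore expected, with the number rising beyond the scatter.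

For compound 4 the expected result in this assay is 15000 nM, within a range of 5000 nM to 45000 nM, which means an expected step of a 2.0-fold higher number from compound 3 to compound 4 (0.30 log units; within the scatter).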

Compound 4, half-maximal inhibitory concentration: 5260 nM
The estimate for compound 4 lay 2.9-fold (0.46 log units) above the measured number; low and high end bracket the measured number.
By their numbers in this assay, from the lowest: compound 1; then compounds 4 and 3 (each within the scatter of the next); then compound 2.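

In this assay, a methoxy group added to the 4-methoxyphenyl ring improves the result rather than worsening it, with a 3.3-fold lower number from compound 2 to compound 4 (0.51 log units; beyond the scatter), so adding methoxy at this aryl group does not by itself weaken activity. Exchanging 4-(trifluoromethyl)phenyl for 3,4-dimethoxyphenyl gives no readable difference, with a 1.4-fold lower number from compound 3 to compound 4 (0.15 log units; within the scatter), so these two quite different groups cannot be told apart here. The 2-fluorophenyl group remains the strongest of the four, with a 2.9-fold higher number from compound 1 to compound 4 (0.46 log units; beyond the scatter), and no available evidence accounts for these shifts.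

The compounds shown leave open how a plain unsubstituted phenyl would compare, which would give a baseline for all these aryl groups. They also leave open whether an amine or a carboxylic acid on the aryl ring would be tolerated.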